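From cyclohexyloxy to chlorophenoxy on a shared core

This account rests on a few compounds, and the source may have more. Where it says the series, first, only, none or still open, it means among the compounds named here.

Of the compounds shown here, three built on one shared core have been tested in a functional assay for inhibition of sodium/hydrogen exchanger (Oryctolagus cuniculus); a lower number here means a stronger inhibitor, a higher number a weaker inhibitor. Compound 1 `Cc1cc(C)c(S(C)(=O)=O)cc1C(=O)N=C(N)N` gives 11 nM. Compound 2 `Cc1cc(C2CCCCC2)c(S(C)(=O)=O)cc1C(=O)N=C(N)N` gives 22 nM. Compound 3 `Cc1cc(OC2CCCCC2)c(S(C)(=O)=O)cc1C(=O)N=C(N)N` gives 37 nM. Compound 3 holds the highest of the three numbers; the smaller gap, a 1.7-fold higher number from compound 2 to compound 3 (0.23 log units; within the scatter), stays within the scatter, whereas the larger one, a 3.4-fold higher number from compound 1 to compound 3 (0.53 log units; beyond the scatter), lies beyond it. The remaining comparison, a 2.0-fold higher number from compound 1 to compound 2 (0.30 log units; within the scatter), also stays within the scatter.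

Compound 4 `Cc1cc(Oc2cccc(Cl)c2)c(S(C)(=O)=O)cc1C(=O)N=C(N)N` has not yet been measured. It differs from compound 3 in one place: 3-chlorophenyl in place of cyclohexyl on an oxygen on an aromatic ring. Among the measured compounds shown here, no measured step swaps a saturated ring for an aromatic one on that oxygen, so nothing measured speaks to this change directly. The two steps that involve the cyclohexyloxy group, a 3.4-fold higher number from compound 1 to compound 3 (0.53 log units; beyond the scatter) and a 1.7-fold higher number from compound 2 to compound 3 (0.23 log units; within the scatter), were modest or within the scatter, which suggests that changes at this position move the number only a little. The step is therefore expected to be small and in no settled direction, as the estimated 1.1-fold higher number from compound 3 to compound 4 (0.03 log units; within the scatter) expresses. Compound 4 is expected to give about 40 nM in this assay, with a range from 15 nM to 120 nM.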

Compound 4, half-maximal inhibitory concentration: 21 nM
For compound 4 the middle estimate is 1.9-fold (0.28 log units) above the measured one; the measured number falls inside the stated range.
By their numbers in this assay, from the lowest: compounds 1, 4, 2 and 3 (each within the scatter of the next, the first and the last beyond it).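

In this assay the swap of a saturated ring for an aromatic one on this oxygen, 3-chlorophenyl in place of cyclohexyl, gives a 1.8-fold lower number from compound 3 to compound 4 (0.25 log units; within the scatter) and so does not separate the two rings. The 3-chlorophenoxy group also cannot be told apart from a cyclohexyl attached directly to the aromatic carbon, with a 1.0-fold lower number from compound 2 to compound 4 (0.02 log units; within the scatter) on record, or from methyl, with a 1.9-fold higher number from compound 1 to compound 4 (0.28 log units; within the scatter) on record, so this position accepts a group of this size as well. Compound 3 is the one exception, since a 3.4-fold higher number from compound 1 to compound 3 (0.53 log units; beyond the scatter) is the only step among these compounds that lies beyond the scatter, and compound 4 shows that this gap from methyl does not carry over to every ring attached through oxygen.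

Nothing shown here gives a cause for any of these numbers. Going by these compounds, how an amine or a carboxylic acid at this position would read stays open, and so does what the chlorine contributes, which a plain phenoxy group would test.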